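Saturating the amide side chain of a urotensin receptor agonist

This account rests on a few compounds, and the source may have more. Where it says the series, first, only, none or still open, it means among the compounds named here.

Compound 1, `COc1ccc(CCC(=O)NC(CCN(C)C)c2ccc3ccccc3c2)cc1`: in a functional assay on NIH3T3 cells for agonist activity at Urotensin-2 receptor (Homo sapiens), with a stated time of 5 days (on this read-out lower numbers stand for an effect already at smaller amounts and higher numbers for an effect only at larger amounts of compound), compound 1 gives 1410 nM.
Compound 2, `CN(C)CCC(NC(=O)/C=C/c1ccccc1)c1ccc2ccccc2c1`: compound 2 gives 589 nM.
Compound 3, `CN(C)CCC(NC(=O)C#Cc1ccccc1)c1ccc2ccccc2c1`: compound 3 gives 457 nM.

Compound 3 shows the lowest number of the three, but its gap to compound 2 is within the scatter, so the two cannot be ordered; only compound 1 stands clearly apart from it. The change to compound 4, `CN(C)CCC(NC(=O)CCc1ccccc1)c1ccc2ccccc2c1`, is phenethyl in place of 2-phenylethynyl on a carbonyl carbon. Among the compounds with values here, no measured step covers this saturation directly. The nearest step, a 1.3-fold lower number from compound 2 to compound 3 (0.11 log units; within the scatter), shows that removing unsaturation in one stage changed little. Compound 1, which also carries a phenethyl chain, though with an added methoxy group, gives a higher number than compound 3. Weighing both, compound 4 is expected to land between them, with a 2.1-fold higher number from compound 3 to compound 4 (0.32 log units; beyond the scatter) as the expected step. The estimate for compound 4 is 950 nM, ranging from 400 nM to 2300 nM.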

Compound 4, half-maximal effective concentration: 603 nM
Compound 4: middle estimate off by 1.6-fold (0.20 log units), on the high side; the range from low to high includes it.
By their numbers in this assay, from the lowest: compounds 3, 2 and 4 (each within the scatter of the next); then compound 1.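

Replacing 2-phenylethynyl or 2-phenylethenyl with phenethyl on the carbonyl carbon has no readable effect in this assay (a 1.3-fold higher number from compound 3 to compound 4 (0.12 log units; within the scatter); a 1.0-fold higher number from compound 2 to compound 4 (0.01 log units; within the scatter)), so the triple-bonded, double-bonded and saturated chains cannot be told apart here. Hydrogen in place of methoxy on an aromatic carbon gives the only new step beyond the scatter, and a modest one (a 2.3-fold lower number from compound 1 to compound 4 (0.37 log units; beyond the scatter)). Nothing available explains either result.

From the compounds shown here alone, it remains open whether a longer chain on the carbonyl carbon would keep the number in this range. Going by these compounds, it is also open whether a fluorine or a carboxylic acid on that aromatic carbon would behave like methoxy or like hydrogen.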